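Shifting the Nitro Group Along a Phenyl Ether

A few compounds are considered here, and "the series" means these few. Any claim that something is new, unique, unknown or untested is made for them only; others in the source may bear on it.

In a functional assay on MCF7 cells (Homo sapiens) for antiproliferative activity (a higher number here means a weaker inhibitor, a lower number a stronger inhibitor), compound 1 `N#CN/C(=N\CCCCCCOc1ccccc1)Nc1ccncc1` gives 30 nM and compound 2 `N#CN/C(=N\CCCCCCOc1ccccc1[N+](=O)[O-])Nc1ccncc1` gives 6.3 nM as its reading. Compound 3 `N#CN/C(=N\CCCCCCOc1cccc([N+](=O)[O-])c1)Nc1ccncc1` gives 31 nM and so stands within the scatter of compound 1, with a higher number than compound 2.

Compound 4 `N#CN/C(=N\CCCCCCOc1ccc([N+](=O)[O-])cc1)Nc1ccncc1` differs from compound 3 by one change: 4-nitrophenyl in place of 3-nitrophenyl on an oxygen on a saturated carbon with 4-nitrophenyl in place of 3-nitrophenyl on an oxygen on a saturated carbon.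

Going by the values given here, three measured steps bear on this. Adding nitro gave a 4.8-fold lower number from compound 1 to compound 2 (0.68 log units; beyond the scatter) in one case and a 1.0-fold higher number from compound 1 to compound 3 (0.01 log units; within the scatter) in the other, while the switch from 2-nitrophenyl to 3-nitrophenyl gave a 4.9-fold higher number from compound 2 to compound 3 (0.69 log units; beyond the scatter) as its result. Among the compounds with values here, the effect of nitro thus differs between these compounds, and no measured compound carries 4-nitrophenyl, so the direction is poorly defined. An estimated step of a 1.4-fold lower number from compound 3 to compound 4 (0.15 log units; within the scatter) is expected, which stays within the scatter.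

Compound 4 is expected at 22 nM in this assay with 7 nM to 70 nM as its estimated range.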

Compound 4, half-maximal inhibitory concentration: 120 nM
The estimate for compound 4 lay 5.5-fold (0.74 log units) below the measured number, outside the stated range (above it).
By their numbers in this assay, from the lowest: compound 2; then compounds 1 and 3 (each within the scatter of the next); then compound 4.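

In this assay the switch to 4-nitrophenyl gave a 3.9-fold higher number from compound 3 to compound 4 (0.59 log units; beyond the scatter) and a 19-fold higher number from compound 2 to compound 4 (1.28 log units; beyond the scatter), so the three nitro isomers now separate, with compound 3 lying between compound 2 and compound 4. Adding nitro to the phenyl ether now has three different outcomes: a lower number in compound 2, no shift beyond the scatter in compound 3, and a 4.0-fold higher number from compound 1 to compound 4 (0.60 log units; beyond the scatter) in the last case. Nothing available here accounts for this difference between the isomers.

The compounds shown leave open whether another group on the ring, such as an amine or a carboxylic acid in place of nitro, would follow the same order across these ring places. They also leave open whether that order would hold with a longer chain between the oxygen and the shared core.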